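The compounds below may be only part of what the source reports. "The series", "measured", "known", "first", "only" and "open" are said of these compounds alone.

Compound 1 `C/C(=C\CC/C(C)=C/CC[C@@H]1[C@@]2(C)CCC(=O)C(C)(C)[C@H]2CC[C@@]1(C)O)CC/C=C(\C)C(=O)OCc1cn(-c2cccc(O)c2)nn1` carries at the end of its ester side chain a five-membered aromatic ring with 3 nitrogen, and on one of those nitrogens a 3-hydroxyphenyl group. In a functional assay on DU-145 cells (Homo sapiens) for antiproliferative activity, read by MTT assay, with a stated time of 48 h (a higher number here means a weaker inhibitor, a lower number a stronger inhibitor), compound 1 gives 28400 nM. Compound 2 `C/C(=C\CC/C(C)=C/CC[C@@H]1[C@@]2(C)CCC(=O)C(C)(C)[C@H]2CC[C@@]1(C)O)CC/C=C(\C)C(=O)OCc1cn(C[C@@H]2O[C@H](n3ccc(=O)[nH]c3=O)[C@H]3OC(C)(C)O[C@H]32)nn1` bears a protected nucleoside in place of that phenyl. In this assay compound 2 reaches only the limit of the measurement, > 150000 nM. Compound 3 `COc1cccc(-n2cc(COC(=O)/C(C)=C/CC/C(C)=C/CC/C(C)=C/CC[C@@H]3[C@@]4(C)CCC(=O)C(C)(C)[C@H]4CC[C@@]3(C)O)nn2)c1` is the methyl ether of compound 1. In this assay compound 3 also stops at the limit, > 150000 nM. Among the compounds with values here, the one step that can be read, an at least 5.2-fold higher number from compound 1 to compound 3 (0.72 log units; beyond the scatter), shows that capping the phenol with methyl removes measurable activity, and with two of the three values sitting at the limit of > 150000 nM in this assay, at which 2 of the 3 values shown sit, compound 3 stands at the weak end of everything seen so far. Compound 4 `C/C(=C\CC/C(C)=C/CC[C@@H]1[C@@]2(C)CCC(=O)C(C)(C)[C@H]2CC[C@@]1(C)O)CC/C=C(\C)C(=O)OCc1cn(-c2ccccc2Br)nn1` alters the same position: 2-bromophenyl in place of 3-methoxyphenyl on an aromatic nitrogen. Within the data shown here, the 2-bromophenyl of compound 4, like the 3-methoxyphenyl of compound 3, has no hydrogen-bond donor, and the only measured step bearing on this position points toward loss rather than gain. Compound 4 is therefore expected to show little change, an at least 1.2-fold lower number from compound 3 to compound 4 (0.09 log units; that floor lies within the scatter), and its estimated value in this assay is 120000 nM, within a range of 30000 nM to 400000 nM.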

Compound 4, half-maximal inhibitory concentration: > 150000 nM
Compound 4 was reported as a limit (the forecaster's own chance of this, stated with the estimate: 60%); middle value at least 1.2-fold (0.09 log units) from the limit.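

In this assay, within the data shown here, 2-bromophenyl in place of 3-hydroxyphenyl gives an at least 5.2-fold higher number from compound 1 to compound 4 (0.72 log units; beyond the scatter), so the methyl ether is no longer the only change at this position that loses a measurable value. The value of compound 4 is a limit of the measurement and not a number, and the step between compound 3 and compound 4 cannot be read, which leaves the 2-bromophenyl and the 3-methoxyphenyl unranked. Among the compounds with a phenyl on the aromatic nitrogen, only the 3-hydroxyphenyl of compound 1 now gives a number, and the rest of the series offers no other value to compare with it: the limit of > 150000 nM in this assay, at which 3 of the 4 values shown sit.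

On these data alone, what remains open is whether the free hydroxyl itself or some other feature of the 3-hydroxyphenyl group accounts for the activity of compound 1, since compound 4 differs from it both in the substituent and in where that substituent sits. The compounds shown also do not tell how an unsubstituted phenyl, or a phenyl carrying an amine or a carboxylic acid in place of the hydroxyl, would behave in this assay.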